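Swapping a Sulfur Chain for an Aminopiperidine

A few compounds are considered here, and "the series" means these few. Any claim that something is new, unique, unknown or untested is made for them only; others in the source may bear on it.

Measured compounds:
compound 1, `Cc1ccc(-c2ccc(C(=O)N=C(N)N)cc2S(C)(=O)=O)cc1`: 100 nM
compound 2, `Cc1cc(-c2cc(C(F)(F)F)cc(C(F)(F)F)c2)c(S(C)(=O)=O)cc1C(=O)N=C(N)N`: 2800 nM
compound 3, `CCSc1cc(C)c(C(=O)N=C(N)N)cc1S(C)(=O)=O`: 5.9 nM

In a functional assay for inhibition of sodium/hydrogen exchanger (Oryctolagus cuniculus) (on this read-out lower numbers stand for stronger inhibition and higher numbers for weaker inhibition), compound 3 gives the lowest number of the three; compound 1 sits a good way above it, and compound 2 sits far above, both gaps beyond the scatter. Compound 4, `Cc1cc(N2CCC(N)CC2)c(S(C)(=O)=O)cc1C(=O)N=C(N)N`, is the untested relative of compound 3. The change is 4-aminopiperidin-1-yl in place of ethylsulfanyl on an aromatic carbon. No direct comparison of this kind exists among the measured compounds, so the size of the step is uncertain. A larger group at this carbon has not gone well in compound 1 and compound 2, so a loss of potency is expected, a 10-fold higher number from compound 3 to compound 4 (1.01 log units; beyond the scatter). For compound 4 the expected value is 60 nM, within a range from 10 nM to 400 nM.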

Compound 4, half-maximal inhibitory concentration: 9.8 nM
For compound 4 the middle estimate is 6.1-fold (0.79 log units) above the measured one; measured number below the stated range.
By their numbers in this assay, from the lowest: compounds 3 and 4 (each within the scatter of the next); then compound 1; then compound 2.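

In this assay the exchange of ethylsulfanyl for 4-aminopiperidin-1-yl gives a 1.7-fold higher number from compound 3 to compound 4 (0.22 log units; within the scatter), so this aromatic carbon, ortho to the methylsulfonyl group, can carry a six-membered non-aromatic ring with an amine and keep the number of compound 3 within the scatter. The earlier compounds shown here offered no comparison in one place at this carbon. No evidence at hand offers an explanation for this result.

The compounds shown leave open whether the amine on the ring matters. A plain piperidin-1-yl, an acetamide or a carboxylic acid in its place would test this.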